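The compounds below may be only part of what the source reports. "The series", "measured", "known", "first", "only" and "open" are said of these compounds alone.

Compound 1 `O=C(/C=C/c1ccc2c(c1)B(O)OC2)c1ccccc1` carries hydrogen at the varied position of the six-membered aromatic ring of carbon only; in a functional assay on HCT-116 cells (Homo sapiens) for cytotoxicity, read by MTT assay, with a stated time of 48 h (a higher number here means a weaker inhibitor, a lower number a stronger inhibitor), compound 1 gives 6100 nM. Compound 2 `O=C(/C=C/c1ccc2c(c1)B(O)OC2)c1cccc(F)c1` bears fluoro at that position, and in this assay compound 2 gives 6700 nM. Compound 3 `Cc1cccc(C(=O)/C=C/c2ccc3c(c2)B(O)OC3)c1` bears methyl there, and in this assay compound 3 gives 6700 nM. Compound 3 thus stands level with compound 2 at the digits shown and within the scatter of compound 1; the three numbers are not separated from one another.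

Compound 4 `COc1cccc(C(=O)/C=C/c2ccc3c(c2)B(O)OC3)c1` differs from compound 3 by methoxy in place of methyl on an aromatic carbon. The measured steps that bear on this change are a 1.1-fold higher number from compound 1 to compound 3 (0.04 log units; within the scatter), no change at the digits printed from compound 2 to compound 3 (within the scatter) and a 1.1-fold higher number from compound 1 to compound 2 (0.04 log units; within the scatter). Within the data shown here, no substitution at this position has so far moved the number beyond the scatter, and no measured compound carries a group with a hydrogen-bond acceptor at this position, so methoxy has no direct precedent. For compound 4 the expected step is no change at the digits printed from compound 3 to compound 4 (within the scatter), none beyond the scatter. Compound 4 is estimated at 6700 nM, with a range from 3300 nM to 13500 nM.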

Compound 4, half-maximal inhibitory concentration: 5000 nM
For compound 4 the middle estimate is 1.3-fold (0.13 log units) above the measured one; the measured number falls inside the stated range.
By their numbers in this assay, from the lowest: compounds 4, 1, 2 and 3 (each within the scatter of the next).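

In this assay, methoxy brings the first hydrogen-bond acceptor to this position, yet a 1.3-fold lower number from compound 3 to compound 4 (0.13 log units; within the scatter) and a 1.3-fold lower number from compound 2 to compound 4 (0.13 log units; within the scatter) and a 1.2-fold lower number from compound 1 to compound 4 (0.09 log units; within the scatter) all lie within the scatter. The position on the six-membered aromatic ring of carbon only has therefore taken hydrogen, fluoro, methyl and methoxy, including a group of two heavy atoms, without any step beyond the scatter, so neither the added oxygen nor the hydrogen-bond acceptor separates compound 4 from the other compounds in this series. No measurement is available that would offer an explanation for this flat result.

The compounds shown leave open whether an amine, a carboxylic acid or a longer chain such as butoxy at this position would move the number beyond the scatter, and so whether the position is sensitive to substitution at all. They also leave open whether fluoro, methyl or methoxy would give the same flat result elsewhere on this ring, as each of these groups stands here only meta to a large group.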